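A few compounds are considered here, and "the series" means these few. Any claim that something is new, unique, unknown or untested is made for them only; others in the source may bear on it.

Measured compounds in this series:

compound 1 `CC1(OC(=O)N2CCC(O[C@H]3CC[C@H](Oc4cnc(S(C)(=O)=O)cn4)CC3)CC2)CC1` — 138 nM
compound 2 `CS(=O)(=O)c1cnc(O[C@H]2CC[C@H](OC3CCN(C(=O)C4(C(F)(F)F)CC4)CC3)CC2)cn1` — 1380 nM

In a functional assay on isolated protein for agonist activity at Glucose-dependent insulinotropic receptor (Rattus norvegicus), read by HTRF and cAMP accumulation (on this read-out higher numbers stand for an effect only at larger amounts of compound and lower numbers for an effect already at smaller amounts), compound 2 stands at the highest of the two numbers; the nearest is compound 1, separated by a 10-fold higher number from compound 1 to compound 2 (1.00 log units; beyond the scatter), a step beyond the usual scatter of repeated measurements.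

Compound 3 `CC(C)c1noc(CN2CCC(O[C@H]3CC[C@H](Oc4cnc(S(C)(=O)=O)cn4)CC3)CC2)n1` is the next member. Relative to compound 2 the change is (3-isopropyl-1,2,4-oxadiazol-5-yl)methyl in place of (1-(trifluoromethyl)cyclopropyl)carbonyl on an amine nitrogen in a ring. Within the data shown here, the single measured step, a 10-fold higher number from compound 1 to compound 2 (1.00 log units; beyond the scatter), concerns an exchange of the group on the carbonyl carbon of the same ring nitrogen; it shows that this position tolerates a modest shift in this assay, but it does not involve removing the carbonyl itself, so it bears on the new change only indirectly. Among the measured compounds shown here, the data hold no step in which a carbonyl at this ring nitrogen is replaced by a methylene-linked aromatic group, and no second example of a change at this nitrogen.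

On that basis a step of modest size is expected, with the direction uncertain; compound 3 is estimated at 700 nM, within 140 nM to 3500 nM, implying an expected step of a 2.0-fold lower number from compound 2 to compound 3 (0.29 log units; within the scatter).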

Compound 3, half-maximal effective concentration: 97.9 nM
Beside the measured number, compound 3's estimate is 7.2-fold (0.85 log units) above it; measured number below the stated range.
By their numbers in this assay, from the lowest: compounds 3 and 1 (each within the scatter of the next); then compound 2.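

In this assay, a carbonyl on the ring amine nitrogen proves not to be needed: the exchange for (3-isopropyl-1,2,4-oxadiazol-5-yl)methyl gives a 14-fold lower number from compound 2 to compound 3 (1.15 log units; beyond the scatter) and thus reverses the loss seen with the earlier change at this nitrogen. Measured against the ((1-methylcyclopropyl)oxy)carbonyl group, the same entering group gives a 1.4-fold lower number from compound 1 to compound 3 (0.15 log units; within the scatter) so these two quite different groups cannot be told apart in this assay even though only one of them holds an aromatic ring. Among the three groups on this nitrogen, the (1-(trifluoromethyl)cyclopropyl)carbonyl of compound 2 alone stands apart, with a 10-fold higher number from compound 1 to compound 2 (1.00 log units; beyond the scatter) as its step from the carbamate-bearing member of the series.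

Nothing among the available data gives a cause for the size of the step to compound 3.
On these data alone, it remains open whether the 1,2,4-oxadiazole ring matters in itself or whether the removal of the carbonyl suffices, which a benzyl group on the same nitrogen would address, and whether the isopropyl group on that ring could give way to a cyclopropyl or a tert-butyl group without a step beyond the scatter.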